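Bromo in Place of Hydrogen, Twice in One Series

A few compounds are considered here, and "the series" means these few. Any claim that something is new, unique, unknown or untested is made for them only; others in the source may bear on it.

Compound 1, `C#CCOc1ccccc1/C=N/Cc1ccc(S(N)(=O)=O)cc1`: 31000 nM
Compound 2, `C#CCOc1ccc(Br)cc1/C=N/Cc1ccc(S(N)(=O)=O)cc1`: 45700 nM
Compound 3, `NS(=O)(=O)c1ccc(C/N=C/c2ccccc2OCc2cn(CCCOc3ccc4ccc(=O)oc4c3)nn2)cc1`: 14300 nM

In a functional assay on HT-29 cells (Homo sapiens) for cytotoxicity, read by MTT assay, with a stated time of 24 h (a lower number here means a stronger inhibitor, a higher number a weaker inhibitor), compound 1 gives 31000 nM and compound 2 gives 45700 nM. The change between them is bromo in place of hydrogen on an aromatic carbon, and the step it made was a 1.5-fold higher number from compound 1 to compound 2 (0.17 log units; within the scatter). Compound 3 gives 14300 nM in this assay; how its core differs from that of compound 1 is not broken down here. Compound 4, `NS(=O)(=O)c1ccc(C/N=C/c2cc(Br)ccc2OCc2cn(CCCOc3ccc4ccc(=O)oc4c3)nn2)cc1`, is not yet measured. It differs from compound 3 by bromo in place of hydrogen on an aromatic carbon. This is the same kind of change as that from compound 1 to compound 2, not the same: in compound 2 the bromo sits para to a propargyloxy group (4 heavy atoms), in compound 4 para to a large group. Since the earlier step was a 1.5-fold higher number from compound 1 to compound 2 (0.17 log units; within the scatter), a step of a 1.4-fold higher number from compound 3 to compound 4 (0.15 log units; within the scatter) is expected here. Compound 4 is thus estimated at 20000 nM, between 9000 nM and 45000 nM.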

Compound 4, half-maximal inhibitory concentration: 17700 nM
For compound 4 the middle estimate is 1.1-fold (0.05 log units) above the measured one; low and high end bracket the measured number.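

In this assay the new step is a 1.2-fold higher number from compound 3 to compound 4 (0.09 log units; within the scatter) and so matches the earlier result in kind, with bromo in place of hydrogen leaving the number within the scatter on both cores. The two steps agree with each other: the same change on two cores in this assay, a 1.5-fold higher number (0.17 log units; within the scatter) from compound 1 to compound 2 and a 1.2-fold higher number (0.09 log units; within the scatter) from compound 3 to compound 4, 1.2-fold (0.08 log units) apart, within the scatter of two such steps. This shows that the small step carries from the core of compound 1 to the core of compound 3, but it does not show that bromo changes cytotoxicity on either core, or that the agreement extends to any other core.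

The compounds shown leave open how a chloro, a methoxy or an amine on that aromatic carbon would read. They also leave open whether a longer chain in the large group would alter the step.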